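This account rests on a few compounds, and the source may have more. Where it says the series, first, only, none or still open, it means among the compounds named here.

Four compounds are compared here, and all of them were tested, or are to be tested, in an ADME assay on H9 cells (Homo sapiens) for cytotoxicity, read by XTT assay, with a stated time of 6 days; a higher number here means that more compound is tolerated, a lower number that less compound is tolerated. Compound 1 `Cc1cc(C#N)cc(C)c1Oc1cc(Nc2ccc(C#N)cc2)c(N)cc1N` and compound 2 `Cc1cc(C)c(Oc2cc(Nc3ccc(C#N)cc3)c(N)cc2N)c(C)c1` share one core. In this assay compound 2 gives 50000 nM. In this assay compound 1 gives 51000 nM. The two differ in a single place, (cyano in place of methyl on an aromatic carbon), and that change made a step of a 1.0-fold higher number from compound 2 to compound 1 (0.01 log units; within the scatter).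

Compound 3 `Cc1cc(C)c(Oc2cc(Nc3ccc(C#N)cc3)c([N+](=O)[O-])cc2[N+](=O)[O-])c(C)c1` is built on a different core; the difference between the two cores is not broken down here. In this assay compound 3 reaches only a limit of the assay, > 59800 nM. This is the limit of > 59800 nM in this assay, at which 1 of the 3 values shown sits.

Compound 4 `Cc1cc(C#N)cc(C)c1Oc1cc(Nc2ccc(C#N)cc2)c([N+](=O)[O-])cc1[N+](=O)[O-]` has not yet been measured in this assay. It differs from compound 3 by cyano in place of methyl on an aromatic carbon, the same change that separates compound 2 from compound 1. Because that change left the number where it was in the measured pair a 1.0-fold higher number from compound 2 to compound 1 (0.01 log units; within the scatter), the step that the limit leaves unreadable from compound 3 to compound 4 is expected to be small as well. The expectation for compound 4 in this assay is a value near 60000 nM, most likely between 30000 nM and 120000 nM, and it is expected that compound 4, like compound 3, will be reported only as a limit rather than as a number.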

Compound 4, half-maximal cytotoxic concentration: > 58200 nM
Compound 4 was reported as a limit; the forecaster's own chance of this, stated with the estimate: 70%; the middle value is on the limit's open side.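

Among these compounds, neither compound 3 nor compound 4 gives a number in this assay, only a limit, so no step between them can be read. Still open, from the compounds shown here alone, is how much compound either one tolerates past its limit, and whether cyano in place of methyl on an aromatic carbon does as little on their core as on the other, where it made a 1.0-fold higher number from compound 2 to compound 1 (0.01 log units; within the scatter).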